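Hydroxy for azido on a selenium-containing sugar ring

The source may hold more compounds than are shown below. What is called first, only, known or untested is meant among the compounds shown, and "the series" means these compounds.

Four compounds share a five-membered non-aromatic ring with one selenium, carrying a hydroxymethyl group and a hydroxy group, with a base attached to the ring. Compound 1 `Cc1cn(C2[Se][C@H](CO)[C@@H](O)[C@@H]2N=[N+]=[N-])c(=O)[nH]c1=O` bears an azido group on a saturated ring carbon, and compound 2 `Cc1cn(C2[Se][C@H](CO)[C@@H](O)[C@@H]2O)c(=O)[nH]c1=O` carries a hydroxy group at that carbon instead. Compound 3 `[N-]=[N+]=N[C@@H]1C(n2ccc(N)nc2=O)[Se][C@H](CO)[C@H]1O` carries the azido group on a different core, and compound 4 `Nc1ccn(C2[Se][C@H](CO)[C@@H](O)[C@@H]2O)c(=O)n1` is its hydroxy counterpart. The difference between the core of compound 1 and the core of compound 3 is not broken down here.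

In a functional assay on HCT-116 cells (Homo sapiens) for cytotoxicity, read by sulforhodamine B assay (a higher number here means a weaker inhibitor, a lower number a stronger inhibitor), compound 1 gives > 100000 nM, which is a limit of the assay and not a number. Compound 2 gives > 100000 nM in this assay, again a limit. Two of the three measured values therefore sit at the limit of > 100000 nM in this assay, at which 2 of the 3 values shown sit. The step that the two limits leave unreadable from compound 1 to compound 2 cannot be read as a size; the change itself is hydroxy in place of azido on a saturated ring carbon. Going by the values given here, compound 3 gives 78300 nM in this assay, the only true number in the set.

The change from compound 3 to compound 4 is hydroxy in place of azido on a saturated ring carbon. It is the same kind of change as that from compound 1 to compound 2; the two places differ only in that the ring atom next to the changed carbon bears a group of 8 heavy atoms in compound 3 rather than a group of 9 heavy atoms in compound 1.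

The step is expected to be small, a 1.3-fold higher number from compound 3 to compound 4 (0.11 log units; within the scatter), since the measured pair gives no readable size (a step that the two limits leave unreadable from compound 1 to compound 2). Compound 4 is thus estimated at 100000 nM, with a likely range from 40000 nM to 300000 nM, and a limit rather than a number is quite possible.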

Compound 4, half-maximal inhibitory concentration: 7130 nM
Beside the measured number, compound 4's estimate is 14-fold (1.15 log units) above it; the whole stated range lies above it.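

On the core of compound 3, hydroxy in place of azido on a saturated ring carbon gives an 11-fold lower number from compound 3 to compound 4 (1.04 log units; beyond the scatter) in this assay, so on this core the change is large and goes towards a stronger inhibitor. The same change on the core of compound 1 has no readable size, and the data therefore show neither that this gain carries over to that core nor that it fails to, as both ends of that pair are limits of the assay and not numbers: the limit of > 100000 nM in this assay, at which 2 of the 4 values shown sit.

What can be said is therefore narrow: a single readable step, on a single core, supports a statement about compound 3 and compound 4 and is no rule for the series as a whole.

The compounds shown leave open how an amine or a single fluorine atom on that same saturated ring carbon would compare with hydroxy and azido on either core. They also leave open whether the step seen on the core of compound 3 would appear again with a base that carries a longer chain in place of the methyl group of compound 1.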